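Changing the sulfur side chain of compound 3

The source may report more compounds than this note shows. Statements on the series, on what has been measured and on what is new or still open speak of the compounds shown alone.

Measured in a functional assay on HT-29 cells (Homo sapiens) for inhibition, read by MTT assay, with a stated time of 48 h; a higher number here means a weaker inhibitor, a lower number a stronger inhibitor:
compound 1 `COc1cc(-c2nnc(S)n2-c2ccc(N(C)C)cc2)cc(OC)c1OC`: > 60000 nM
compound 2 `COc1cc(-c2nnc(SCc3ccc(C)cc3)n2-c2ccc(N(C)C)cc2)cc(OC)c1OC`: 27500 nM
compound 3 `COc1cc(-c2nnc(SCc3ccc(F)cc3)n2-c2ccc(N(C)C)cc2)cc(OC)c1OC`: 44300 nM

Compound 1, with only hydrogen on its sulfur, gives > 60000 nM, which is a limit and not a number. That leaves two true numbers, and compound 3 cannot be told apart from compound 2: a 1.6-fold higher number from compound 2 to compound 3 (0.21 log units; within the scatter).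

The untested compound 4 `COc1ccc(C(=O)CSc2nnc(-c3cc(OC)c(OC)c(OC)c3)n2-c2ccc(N(C)C)cc2)cc1O` alters compound 3 on a saturated chain carbon bound to a sulfur: (3-hydroxy-4-methoxyphenyl)carbonyl in place of 4-fluorophenyl on a saturated chain carbon bound to a sulfur.

Two measured steps put a group on that sulfur: an at least 2.1-fold lower number from compound 1 to compound 2 (0.33 log units; beyond the scatter), and an at least 1.3-fold lower number from compound 1 to compound 3 (0.13 log units; that floor lies within the scatter). Only the first is beyond the scatter, and both point towards lower numbers, so a lower number is the modest expectation here. Among the measured compounds shown here, none of the measured steps brings in a carbonyl or a hydroxy group, so the size of the change remains uncertain.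

The expected change is a 4.4-fold lower number from compound 3 to compound 4 (0.65 log units; beyond the scatter). For compound 4 the estimate is 10000 nM, within an expected range of 600 nM to 60000 nM.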

Compound 4, half-maximal inhibitory concentration: > 60000 nM
Compound 4 was reported as a limit; the forecaster's own chance of this, stated with the estimate: 12%; middle value at least 6.0-fold (0.77 log units) from the limit.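

Compound 4 gives > 60000 nM in this assay, which is a limit of the assay and not a number. Among the compounds shown here, this is the first compound with a group on the sulfur that does not read as a true number, so a group there does not by itself go with a lower number. (3-hydroxy-4-methoxyphenyl)carbonyl in place of 4-methylphenyl on that saturated chain carbon gives an at least 2.1-fold higher number from compound 2 to compound 4 (0.33 log units; beyond the scatter), while the same group in place of 4-fluorophenyl gives only an at least 1.3-fold higher number from compound 3 to compound 4 (0.13 log units; that floor lies within the scatter). The step between the two compounds at the limit cannot be read: the limit of > 60000 nM in this assay, at which 2 of the 4 values shown sit.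

From the compounds shown here alone, the carbonyl, hydroxy and methoxy groups enter together, and which of them goes with the change stays open. Going by these compounds, how an amine or a carboxylic acid on that chain carbon would read in this assay also stays open.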